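A few compounds are considered here, and "the series" means these few. Any claim that something is new, unique, unknown or untested is made for them only; others in the source may bear on it.

Measured compounds:
compound 1 `CC(C)[C@H](NC(=O)CN(c1nc(Cl)nc2[nH]cnc12)C1CC1)C(=O)O` with 31.2% in a functional assay on the whole organism (Tail, strain ICR) with Mus musculus as the target, in the tail flick test, with a stated time of 30 min, at a dose of 25 umol/kg by the oral route; a higher number here means a stronger effect of the compound at the dose given, a lower number a weaker effect;
compound 2 `CSCC[C@H](NC(=O)CN(c1nc(Cl)nc2[nH]cnc12)C1CC1)C(=O)O` with 20.4% in this assay;
compound 3 `CSCC[C@H](NC(=O)CN(c1ncnc2c1ncn2C1CCCCO1)C1CC1)C(=O)OCc1ccccc1` with 30% in this assay.

Compound 4 `CC(C)[C@H](NC(=O)CN(c1ncnc2c1ncn2C1CCCCO1)C1CC1)C(=O)OCc1ccccc1` has not been measured. It differs from compound 3 by isopropyl in place of 2-(methylsulfanyl)ethyl on a saturated chain carbon bound to an amide-type nitrogen and a carbonyl carbon. The same change has been made once before, from compound 2 to compound 1, where it gave a number 10.8 percentage points higher from compound 2 to compound 1 (beyond the scatter). Compound 3 carries a different core and ester from compound 2, and the difference between the two cores is not broken down here. Compound 3 and compound 1 lie within the scatter of each other in this assay.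

For compound 4 a step of about a number 8 percentage points higher from compound 3 to compound 4 (within the scatter) is expected, resting on the step from compound 2 to compound 1, taken as a rough guide only because a number 10.8 percentage points higher from compound 2 to compound 1 (beyond the scatter) is a single observation. Compound 4 is estimated at 38%, between 25% and 51%.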

Compound 4, a percentage reported as activity, at one dose (the size of the read-out at that dose, not a potency): 21.8%
The estimate for compound 4 lay 16.2 percentage points above the measured number; the measured number lies below the stated range.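

In this assay isopropyl in place of 2-(methylsulfanyl)ethyl gave a number 8.2 percentage points lower from compound 3 to compound 4 (within the scatter), which does not repeat the earlier step on the core of compound 1. Set side by side, the two steps differ: the same change on two cores in this assay, a number 10.8 percentage points higher (beyond the scatter) from compound 2 to compound 1 and a number 8.2 percentage points lower (within the scatter) from compound 3 to compound 4, 19 percentage points apart, beyond the scatter of two such steps. The step from one core therefore cannot be carried over to the other in this series, but the result does not show why, as the two pairs differ in both core and acid or ester end, and only two pairs are shown.

The compounds shown leave open whether the step depends on the core or on that end. They also leave open how an amine or a longer alkyl chain would behave in the same place.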